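This account rests on a few compounds, and the source may have more. Where it says the series, first, only, none or still open, it means among the compounds named here.

Measured so far:
compound 1 `Cc1ccc(-c2nn(-c3ccccc3)cc2-c2nc3ccccc3n2S(=O)(=O)c2ccc(Br)cc2)cc1` — in an ADME assay on cells (Hepatocyte, Mus musculus) for cytotoxicity, read by MTT assay, with a stated time of 24 h (a lower number here means that less compound is tolerated, a higher number that more compound is tolerated), compound 1 gives > 300000 nM
compound 2 `Cc1ccc(-c2nn(-c3ccccc3)cc2-c2nc3ccccc3n2S(=O)(=O)c2ccc(C(F)(F)F)cc2)cc1` — compound 2 gives 89300 nM
compound 3 `O=S(=O)(c1ccc(Br)cc1)n1c(-c2cn(-c3ccccc3)nc2-c2ccc(C(F)(F)F)cc2)nc2ccccc21` — compound 3 gives 167000 nM

The value of compound 1 is a limit of the assay, not a number: the limit of > 300000 nM in this assay, at which 1 of the 3 values shown sits. The change from compound 1 to compound 2, (trifluoromethyl in place of bromo on an aromatic carbon), gives an at least 3.3-fold lower number from compound 1 to compound 2 (0.52 log units; beyond the scatter). The cores of compound 1 and compound 3 differ by trifluoromethyl in place of methyl on an aromatic carbon, with an at least 1.7-fold lower number from compound 1 to compound 3 (0.25 log units; that floor lies within the scatter). Compound 4 `O=S(=O)(c1ccc(C(F)(F)F)cc1)n1c(-c2cn(-c3ccccc3)nc2-c2ccc(C(F)(F)F)cc2)nc2ccccc21` is not yet measured in this assay. It differs from compound 3 by trifluoromethyl in place of bromo on an aromatic carbon, the same change as from compound 1 to compound 2, at the same place. On the strength of that earlier step, the step from compound 3 to compound 4 in this assay is expected to be a 3.0-fold lower number from compound 3 to compound 4 (0.48 log units; beyond the scatter). The value for compound 4 is estimated at 55000 nM, expected to lie between 20000 nM and 170000 nM.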

Compound 4, half-maximal cytotoxic concentration: 137000 nM
Compound 4: the middle estimate sits 2.5-fold (0.40 log units) below what was measured; the measured number falls inside the stated range.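

In this assay trifluoromethyl in place of bromo does not carry over unchanged from one core to the other, with a 1.2-fold lower number from compound 3 to compound 4 (0.09 log units; within the scatter) set against the earlier step: the same change on two cores in this assay, an at least 3.3-fold lower number (0.52 log units; beyond the scatter) from compound 1 to compound 2 and a 1.2-fold lower number (0.09 log units; within the scatter) from compound 3 to compound 4, at least 2.7-fold (0.44 log units) apart, beyond the scatter of two such steps. Trifluoromethyl in place of methyl gives the same picture, with a 1.5-fold higher number from compound 2 to compound 4 (0.19 log units; within the scatter) set against its earlier step: the same change on two cores in this assay, an at least 1.7-fold lower number (0.25 log units; that floor lies within the scatter) from compound 1 to compound 3 and a 1.5-fold higher number (0.19 log units; within the scatter) from compound 2 to compound 4, at least 2.7-fold (0.44 log units) apart, beyond the scatter of two such steps. As far as these compounds go, both comparisons rest on compound 1, whose > 300000 nM is a limit of the assay and not a number, so the true size of each earlier step stays unknown, and two cores cannot show how either change behaves across the series.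

The compounds shown carry only bromo, methyl and trifluoromethyl at these two places. From the compounds shown here alone, how an amine or a carboxylic acid at either place would read in this assay remains open.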